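Replacing 2-phenylethenyl with 4-cyanophenyl on the shared core

The compounds below may be only part of what the source reports. "The series", "measured", "known", "first", "only" and "open" are said of these compounds alone.

Measured so far in an ADME assay on HEK293 cells (Homo sapiens) for inhibition, read by MTT assay, with a stated time of 48 h; a higher number here means a weaker inhibitor, a lower number a stronger inhibitor:
- Compound 1 `Cc1ccc(-c2nc3ccccn3c2Sc2ccccc2)cc1`: > 100000 nM (a limit of the assay)
- Compound 2 `C(=C/c1nc2ccccn2c1Sc1ccccc1)\c1ccccc1`: > 100000 nM (a limit of the assay)

In this assay compound 2 stands at > 100000 nM, which is a limit of the assay and not a number. For the measured compounds named here, the series so far offers no exact value: the limit of > 100000 nM in this assay, at which 2 of the 2 values shown sit.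

Compound 3 `N#Cc1ccc(-c2nc3ccccn3c2Sc2ccccc2)cc1` is the next to be read. It carries 4-cyanophenyl in place of 2-phenylethenyl on an aromatic carbon.

Only a step that the two limits leave unreadable from compound 1 to compound 2 bears on this change, so neither a size nor a direction can be taken from it, and no step beyond the scatter is expected in this assay. The estimated step is a number no higher from compound 2 to compound 3 (the limit leaves the size open), and it should be read with caution, since its starting point is a limit.

For compound 3 the expected value is 100000 nM, within an estimated range from 30000 nM to 300000 nM. A further limit rather than a number is the more likely report.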

Compound 3, half-maximal inhibitory concentration: > 100000 nM
Compound 3: only a limit was reported (the forecaster's own chance of this, stated with the estimate: 75%); the middle value lies on the limit itself.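

In this assay compound 3 gives > 100000 nM, a limit of the assay and not a number. The steps from compound 1 and compound 2 to compound 3 therefore cannot be read. Whether 4-methylphenyl, 2-phenylethenyl and 4-cyanophenyl differ at all on the shared core stays open, with a single reading across the series: the limit of > 100000 nM in this assay, at which 3 of the 3 values shown sit.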